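The source may hold more compounds than are shown below. What is called first, only, known or untested is meant among the compounds shown, and "the series" means these compounds.

Measured compounds and their values:
compound 1, `COc1ccc(Cn2c(NCCNC(=N)N)nc(=O)n(Cc3ccc(Br)cc3)c2=O)cc1`, in a functional assay on the whole organism (strain C57Bl/6) for inhibition, with Mus musculus as the target, with a stated time of 180 min, at 48 degrees C (on this read-out higher numbers stand for an effect only at larger amounts of compound and lower numbers for an effect already at smaller amounts), gives 0.00036 nM
compound 2, `COc1ccc(Cn2c(NCCNC(=N)N)nc(=O)n(Cc3ccc(F)cc3)c2=O)cc1`, in this assay gives 0.00031 nM

Compound 2 has the lowest of the two numbers, but its nearest neighbour is compound 1 and the step of a 1.2-fold lower number from compound 1 to compound 2 (0.06 log units; within the scatter) is within the scatter, so the two compounds are not distinguished on this read-out.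

Compound 3, `COc1ccc(Cn2c(NCCNC(=N)N)nc(=O)n(Cc3ccc([N+](=O)[O-])cc3)c2=O)cc1`, is not yet measured. It differs from compound 2 by nitro in place of fluoro on an aromatic carbon. Within the data shown here, the only measured step, a 1.2-fold lower number from compound 1 to compound 2 (0.06 log units; within the scatter), swaps one halogen for another at the same place and hardly moves the number; a nitro group is a different kind of substituent, and no measured pair tests such a change, so that step bears on the question only loosely. The expectation is therefore no step beyond the scatter, with wide uncertainty: compound 3 is estimated at 0.0004 nM, range 0.0001 nM to 0.0016 nM, an expected step of a 1.3-fold higher number from compound 2 to compound 3 (0.11 log units; within the scatter).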

Compound 3, half-maximal effective concentration: 0.048 nM
Compound 3: the middle estimate sits 120-fold (2.08 log units) below what was measured, outside the stated range (above it).
By their numbers in this assay, from the lowest: compounds 2 and 1 (each within the scatter of the next); then compound 3.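

In this assay, the fluoro and bromo compounds could not be told apart, so the position looked tolerant of change, but nitro in this place gives a 150-fold higher number from compound 2 to compound 3 (2.19 log units; beyond the scatter) and a 130-fold higher number from compound 1 to compound 3 (2.12 log units; beyond the scatter). The position is therefore not indifferent to its substituent: both halogens sit together at the low end, and only the 4-nitrobenzyl compound stands apart. Nothing available here accounts for the size of this step.

Open, from the compounds shown here alone, is whether the higher number is specific to nitro or also appears with other groups at this place, such as an amine, a carboxylic acid, a nitrile or plain hydrogen. Also open, going by these compounds, is whether a step of this size persists when another part of the molecule changes, for example with a longer chain carrying the guanidine.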